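The source may report more compounds than this note shows. Statements on the series, on what has been measured and on what is new or still open speak of the compounds shown alone.

Compound 1 `COc1ccc(/C=C\c2cc(OC)c(OC)c(OC)c2)cc1OCc1ccc(CN2CCCC[C@H]2C(=O)O)cc1`: > 10000 nM (a limit of the assay, not a number)
Compound 2 `COc1ccc(/C=C\c2cc(OC)c(OC)c(OC)c2)cc1OCc1ccc(CN2CC[C@H](O)C2)cc1`: 7200 nM
Compound 3 `COc1ccc(/C=C\c2cc(OC)c(OC)c(OC)c2)cc1OCc1ccc(CN2CC[C@@H](C(=O)O)C2)cc1`: 6300 nM

All three results come from a functional assay on MC-38 cells (Mus musculus) for antiproliferative activity, read by CCK-8 assay, with a stated time of 48 h; on this read-out lower numbers stand for stronger inhibition and higher numbers for weaker inhibition. Compound 3 and compound 2 lie within the scatter of each other, as the step of a 1.1-fold lower number from compound 2 to compound 3 (0.06 log units; within the scatter) shows. Compound 1 gives only a limit, so its steps have floors and no sizes: an at least 1.3-fold lower number from compound 1 to compound 2 (0.14 log units; that floor lies within the scatter) and an at least 1.5-fold lower number from compound 1 to compound 3 (0.20 log units; that floor lies within the scatter).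

Compound 4 `COc1ccc(/C=C\c2cc(OC)c(OC)c(OC)c2)cc1OCc1ccc(CN[C@H](C(=O)O)[C@@H](C)O)cc1` is the next compound to compare with compound 3. The change is (1-carboxy-2-hydroxypropyl)amino in place of 3-carboxypyrrolidin-1-yl on a saturated chain carbon bound to an aromatic carbon. Among the measured compounds shown here, the new group has no ring, and no measured compound carries an open-chain group at this place, so the comparison is indirect. The three measured steps all change the group at this same place, and none is shown to lie beyond the scatter. The closest guide is the exchange of groups on the pyrrolidine, a 1.1-fold lower number from compound 2 to compound 3 (0.06 log units; within the scatter), from compound 2 to compound 3.

No shift beyond the scatter is therefore expected in this assay. The expected step is a 1.1-fold higher number from compound 3 to compound 4 (0.05 log units; within the scatter). For compound 4 the estimated value is 7000 nM, with an expected range of 2500 nM to 20000 nM.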

Compound 4, half-maximal inhibitory concentration: > 10000 nM
Compound 4 gave a limit, no number; the forecaster's own chance of this, stated with the estimate: 35%; middle value at least 1.4-fold (0.15 log units) away from the limit.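

In this assay compound 4 gives > 10000 nM, a limit of the assay and not a number, so the only open-chain group shown on a saturated chain carbon bound to an aromatic carbon yields no measured potency: the limit of > 10000 nM in this assay, at which 2 of the 4 values shown sit.

The two readable steps, an at least 1.5-fold higher number from compound 3 to compound 4 (0.20 log units; that floor lies within the scatter) and an at least 1.3-fold higher number from compound 2 to compound 4 (0.14 log units; that floor lies within the scatter), give floors and no sizes, so replacing either pyrrolidine group with (1-carboxy-2-hydroxypropyl)amino is not shown to move the read-out beyond the scatter, and the step between the two compounds that both carry limits cannot be read. No step at this place is yet shown to lie beyond the scatter, which now holds for an open-chain group as well as for the ring groups.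

On these data alone, it remains open whether an open-chain amine without the carboxylic acid, or a longer chain carrying that acid, would give a different result at this place. It also remains open how the two defined stereocentres of (1-carboxy-2-hydroxypropyl)amino bear on the read-out, as the compounds shown include no other stereoisomer of this group.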